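A few compounds are considered here, and "the series" means these few. Any claim that something is new, unique, unknown or untested is made for them only; others in the source may bear on it.

Values in an ADME assay on WI-38 cells (Homo sapiens) for cytotoxicity, read by MTT assay, with a stated time of 3 days; a lower number here means a stronger inhibitor, a higher number a weaker inhibitor:
- compound 1 `CCCCCCCCC#Cc1cn(C/C=C\CN2C(=O)c3ccccc3C2=O)c(=O)[nH]c1=O`: 49000 nM
- compound 2 `CCCCCCCCC#Cc1cn(C/C=C/CN2C(=O)c3ccccc3C2=O)c(=O)[nH]c1=O`: 53000 nM
- compound 3 `CCCCCc1ccc(C#Cc2cn(C/C=C\CN3C(=O)c4ccccc4C3=O)c(=O)[nH]c2=O)cc1`: > 100000 nM, which is a limit and not a number

Compound 2 gives 53000 nM. Within the data shown here, the step of a 1.1-fold higher number from compound 1 to compound 2 (0.03 log units; within the scatter) lies within the scatter, so compound 2 stands level with the only other exact number.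

Compound 4 `O=C1c2ccccc2C(=O)N1C/C=C/Cn1cc(C#CCCc2ccccc2)c(=O)[nH]c1=O` differs from compound 2 by phenyl in place of hexyl on a saturated chain carbon, two bonds along the chain from a triple-bonded carbon.

One measured step also puts an aromatic ring where a chain stood: an at least 2.0-fold higher number from compound 1 to compound 3 (0.30 log units; that floor lies within the scatter). It gives only a floor, and that floor lies within the scatter, so it points only weakly towards a higher number in this assay.

The expected change is small: a 1.4-fold higher number from compound 2 to compound 4 (0.15 log units; within the scatter). For compound 4 the estimate is 75000 nM, with an expected range from 30000 nM to 150000 nM.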

Compound 4, half-maximal inhibitory concentration: 31000 nM
For compound 4 the middle estimate is 2.4-fold (0.38 log units) above the measured one; the measured number falls inside the stated range.
By their numbers in this assay, from the lowest: compounds 4, 1 and 2 (each within the scatter of the next). At a limit, above all of these: compound 3.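

In this assay phenyl in place of hexyl on a saturated chain carbon, two bonds along the chain from a triple-bonded carbon, gives a 1.7-fold lower number from compound 2 to compound 4 (0.23 log units; within the scatter) and so leaves the two compounds level. Compound 3, with 4-pentylphenyl on a triple-bonded carbon, gives > 100000 nM and that is a limit, not a number. Among these compounds, compound 4 therefore supplies the first exact number for an aromatic ring on this side chain, though nothing measured here gives a cause for the step.

As far as these compounds go, whether an amine or a carboxylic acid on that phenyl, or a longer chain carrying it, would move the number beyond the scatter stays open.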